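The source may report more compounds than this note shows. Statements on the series, on what has been measured and on what is new or still open speak of the compounds shown alone.

In a functional assay on A-375 cells (Homo sapiens) for antiproliferative activity, read by MTT assay, with a stated time of 24 h (a higher number here means a weaker inhibitor, a lower number a stronger inhibitor), compound 1 (`COc1cc(OC)c(-c2coc3cc(OCc4ccc([N+](=O)[O-])cc4)ccc3c2=O)cc1OC`) gives > 10000 nM, which is a limit of the assay and not a number. Compound 2 (`COc1cc(OC)c(-c2coc3cc(OCc4ccccc4C#N)ccc3c2=O)cc1OC`) gives 990 nM and compound 3 (`COc1cc(OC)c(-c2coc3cc(OCc4cccc(Cl)c4)ccc3c2=O)cc1OC`) gives 980 nM, so compound 3 stands level with compound 2, with a 1.0-fold lower number from compound 2 to compound 3 (0.00 log units; within the scatter). Both an at least 10-fold lower number from compound 1 to compound 2 (1.00 log units; beyond the scatter) and an at least 10-fold lower number from compound 1 to compound 3 (1.00 log units; beyond the scatter) lie beyond the scatter, but both start from the 4-nitrophenyl group, which is absent here. Compound 4 (`COc1cc(OC)c(-c2coc3cc(OCc4ccccc4Br)ccc3c2=O)cc1OC`) carries 2-bromophenyl in place of 3-chlorophenyl on a saturated chain carbon bound to an oxygen on an aromatic ring. Going by the values given here, the closest precedent is the exchange between compound 2 and compound 3, so no step beyond the scatter is expected in this assay. The expected step is a 1.0-fold higher number from compound 3 to compound 4 (0.01 log units; within the scatter). Compound 4 is estimated at 1000 nM, with an expected range of 400 nM to 3000 nM.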

Compound 4, half-maximal inhibitory concentration: 2850 nM
Estimate against measurement, compound 4: 2.9-fold (0.45 log units) below, and the stated range covers the measured number.
By their numbers in this assay, from the lowest: compounds 3 and 2 (each within the scatter of the next); then compound 4. At a limit, above all of these: compound 1.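

In this assay, this position does respond to the exchange of one substituted phenyl for another: 2-bromophenyl in place of 3-chlorophenyl gives a 2.9-fold higher number from compound 3 to compound 4 (0.46 log units; beyond the scatter), and bromo in place of cyano gives a 2.9-fold higher number from compound 2 to compound 4 (0.46 log units; beyond the scatter). Compound 4 thus separates from the level pair of compound 2 and compound 3, yet the 4-nitrophenyl group remains further off, with an at least 3.5-fold lower number from compound 1 to compound 4 (0.54 log units; beyond the scatter). That last step starts from a limit of the assay and not a number: the limit of > 10000 nM in this assay, at which 1 of the 4 values shown sits.

From the compounds shown here alone, whether the halogen or its place on the ring carries the step stays open, as both change at once. Going by these compounds, how a 2-aminophenyl or 3-carboxyphenyl group would behave here is also open.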